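Swapping fluorine positions on a T-type channel blocker

The source may report more compounds than this note shows. Statements on the series, on what has been measured and on what is new or still open speak of the compounds shown alone.

Compound 1, `O=C(Nc1cc(F)cc(F)c1)N1CCC2(CC1)C(=O)N(c1ccc(F)c(Cl)c1)C2c1ccccn1`: 42 nM
Compound 2, `O=C(Nc1ccc(F)c(F)c1)N1CCC2(CC1)C(=O)N(c1cccc(Cl)c1)C2c1ccccn1`: 118 nM

Both compounds were tested in an assay on HEK293 cells for inhibition of Voltage-dependent T-type calcium channel subunit alpha-1H (Homo sapiens), using a membrane potential dye; a higher number here means a weaker inhibitor, a lower number a stronger inhibitor. Of the two numbers, compound 2 has the higher one, and the gap to compound 1 lies beyond the usual scatter, so compound 2 is the weaker inhibitor of this pair. The two compounds differ in more than one place, however, so no single change can be credited for that gap.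

Compound 3, `O=C(Nc1cc(F)cc(F)c1)N1CCC2(CC1)C(=O)N(c1cccc(Cl)c1)C2c1ccccn1`, has not yet been measured. It is made from compound 2 by the change (3,5-difluorophenyl in place of 3,4-difluorophenyl on an amide-type nitrogen). The rest of the molecule, including the shared core and the chlorophenyl group on the other ring nitrogen, stays as in compound 2. Compound 3 also sits between the two measured compounds in another sense: its aryl group on the amide-type nitrogen matches that of compound 1, while its other aryl group matches compound 2.

Within the data shown here, with no directly comparable step available, the expectation rests on the two values alone. Compound 3 is expected to land between compound 1 and compound 2, with a step of a 1.7-fold lower number from compound 2 to compound 3 (0.23 log units; within the scatter) that is modest and may not clear the scatter. Compound 3 is estimated at 70 nM, within a range from 30 nM to 165 nM.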

Compound 3, half-maximal inhibitory concentration: 3490 nM
Compound 3: middle estimate off by 50-fold (1.70 log units), on the low side; the measured number lies above the stated range.
By their numbers in this assay, from the lowest: compound 1; then compound 2; then compound 3.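

In this assay, moving a single fluorine within the difluorophenyl group on the amide-type nitrogen gives a 30-fold higher number from compound 2 to compound 3 (1.47 log units; beyond the scatter), so this position is far more sensitive than the small structural change suggests, even though the atom count and the counted donors and acceptors stay the same. On the other aryl group, the change of a fluoro to hydrogen on an aromatic carbon gives an 83-fold higher number from compound 1 to compound 3 (1.92 log units; beyond the scatter), which shows that one fluorine there also separates a strong inhibitor from a much weaker one when the 3,5-difluorophenyl group is held constant. Nothing presented here explains why such small edits have such large effects.

From the compounds shown here alone, the pairing of the 3,4-difluorophenyl group with the fluorinated chlorophenyl group of compound 1 remains open, so it is unclear whether the two fluorine effects simply add together or depend on each other. Also open, going by these compounds, is how this position would respond to a plain phenyl, a methoxyphenyl or a pyridyl group on the amide-type nitrogen, which would show whether the sensitivity is specific to the placement of fluorine.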